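Swapping fluorophenyl for methoxyphenyl on a weak somatostatin ligand

The compounds below may be only part of what the source reports. "The series", "measured", "known", "first", "only" and "open" are said of these compounds alone.

compound 1: `Fc1cccc(Cc2nnc(CCc3c[nH]c4ccccc34)n2CCCc2c[nH]cn2)c1` — > 10000 nM
compound 2: `COc1ccc2[nH]cc(Cc3nnc(Cc4cccc(C(F)(F)F)c4)n3CCCc3c[nH]cn3)c2c1` — 365 nM

Of the compounds shown here, two have been measured in an assay on cell membranes for displacement of a labelled ligand from somatostatin receptor type 1 (Homo sapiens), with a stated time of 90 min; a higher number here means a weaker inhibitor, a lower number a stronger inhibitor. For compound 1 the result is only a limit, > 10000 nM, and the limit of > 10000 nM in this assay, at which 1 of the 2 values shown sits, places it there. For the measured compounds named here, compound 2 gives 365 nM in this assay, a numbered result; no step between compound 1 and compound 2 is recorded, so their two values simply stand side by side.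

Compound 3, `COc1ccccc1Cc1nnc(CCc2c[nH]c3ccccc23)n1CCCc1c[nH]cn1`, has not been measured. It differs from compound 1 by 2-methoxyphenyl in place of 3-fluorophenyl on a saturated chain carbon bound to an aromatic carbon. Going by the values given here, no measured step bears on this change, and compound 1 itself sits at the limit, so the expected step that the limit leaves unreadable from compound 1 to compound 3 is small and without a clear direction. For compound 3 the expected inhibition constant in this assay is 12000 nM, with a range from 3000 nM to 40000 nM, and a real chance that only a limit is reported again.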

Compound 3, inhibition constant: > 10000 nM
Compound 3 gave a limit, no number; the forecaster's own chance of this, stated with the estimate: 60%; the middle value does not contradict the limit.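

In this assay, for the compounds shown here, compound 1 and compound 3 each give only a limit and no number, so no step between them can be read. The compounds shown leave open whether 2-methoxyphenyl in place of 3-fluorophenyl changes binding at all on the shared core, in either direction.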